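The source may hold more compounds than are shown below. What is called first, only, known or untested is meant among the compounds shown, and "the series" means these compounds.

Measured in a functional assay on CCRF-CEM cells (Homo sapiens) for antiproliferative activity; a lower number here means a stronger inhibitor, a higher number a weaker inhibitor:
- compound 1 `COc1cc(C(=O)c2sc(-c3ccc(Cl)c(Cl)c3)cc2N)cc(OC)c1OC` gives 290 nM
- compound 2 `COc1cc(C(=O)c2sc(-c3ccc(F)cc3)cc2N)cc(OC)c1OC` gives 15 nM

Compound 2 has the lower of the two numbers. Next is compound 3 `COc1cc(C(=O)c2sc(-c3cccs3)cc2N)cc(OC)c1OC`, which differs from compound 2 as follows: thiophen-2-yl in place of 4-fluorophenyl on an aromatic carbon. In short, thiophen-2-yl stands in place of 4-fluorophenyl on an aromatic carbon. For the measured compounds named here, the only measured step bearing on this change falls on the same carbon: a 19-fold lower number from compound 1 to compound 2 (1.29 log units; beyond the scatter). That step is large and beyond the scatter, so the number can respond strongly to the group at this place. Going by the values given here, it involves two substituted phenyl groups, however, and no measured compound carries a five-membered ring here. Direction is therefore uncertain, though a moderate rise is expected, given that compound 2 already stands at 15 nM. The expected step is a 2.3-fold higher number from compound 2 to compound 3 (0.37 log units; beyond the scatter). For compound 3 the estimated value is 35 nM, with an expected range of 9 nM to 150 nM.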

Compound 3, half-maximal inhibitory concentration: 9.4 nM
For compound 3 the middle estimate is 3.7-fold (0.57 log units) above the measured one; the measured number falls inside the stated range.
By their numbers in this assay, from the lowest: compounds 3 and 2 (each within the scatter of the next); then compound 1.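

In this assay, a five-membered aromatic ring with one sulfur serves on this carbon as well as a six-membered one: there is a 1.6-fold lower number from compound 2 to compound 3 (0.20 log units; within the scatter), so thiophen-2-yl and 4-fluorophenyl cannot be told apart here. Against 3,4-dichlorophenyl the same ring gives a 31-fold lower number from compound 1 to compound 3 (1.49 log units; beyond the scatter), so the large change at this place now appears with two different replacements of 3,4-dichlorophenyl, and a phenyl ring is not required for a low number. Nothing measured on hand explains either step.

The compounds shown leave open whether this carbon accepts anything other than an aromatic ring, such as a morpholine, a carboxylic acid or a short alkyl chain. Also open, going by these compounds, is whether furan-2-yl or thiophen-3-yl would match thiophen-2-yl, and whether a single chlorine on the phenyl ring would fall with compound 2 or with compound 1.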